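Cytotoxicity of a Catechol Sulfonamide After Swapping Its Urea Arm

This account rests on a few compounds, and the source may have more. Where it says the series, first, only, none or still open, it means among the compounds named here.

Compound 1 `O=[N+]([O-])c1ccc(NC(=S)N2CCN(S(=O)(=O)c3sccc3-c3ccccc3Oc3ccc(O)c(O)c3)CC2)cc1` was tested in an ADME assay on HEK-293T cells (Homo sapiens) for cytotoxicity, read by CCK-8 assay, with a stated time of 48 h; on this read-out higher numbers stand for weaker inhibition and lower numbers for stronger inhibition. In this assay compound 1 gives > 20000 nM, which is a limit of the assay rather than a number. Compound 2 `COc1ccc(NC(=O)NCCNS(=O)(=O)c2ccc(-c3ccccc3Oc3ccc([N+](=O)[O-])cc3)s2)cc1` gives > 20000 nM, again a limit. Compound 3 `Cc1cc(C)cc(NC(=O)NCCNS(=O)(=O)c2ccc(-c3ccccc3Oc3ccc([N+](=O)[O-])c([N+](=O)[O-])c3)s2)c1` gives > 50000 nM, also a limit. Compound 1 therefore sits at the limit of > 20000 nM in this assay, at which 2 of the 3 values shown sit, and no value in this set resolves into a measured number. Compound 4 `O=C(Nc1ccc(F)cc1)N1CCN(S(=O)(=O)c2sccc2-c2ccccc2Oc2ccc(O)c(O)c2)CC1` differs from compound 1 in one place: a group of 10 heavy atoms (7 carbon, 1 nitrogen, 1 oxygen, 1 fluorine; one six-membered aromatic ring of carbon only) in place of a group of 12 heavy atoms (7 carbon, 2 nitrogen, 2 oxygen, 1 sulfur; one six-membered aromatic ring of carbon only), on an amine nitrogen in a ring. No change between two measured compounds is available for comparison, so the expected step is a step that the limit leaves unreadable from compound 1 to compound 4, nothing beyond the scatter. Compound 4 is thus expected to give 40000 nM, between 15000 nM and 150000 nM, most likely reported once more as a limit.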

Compound 4, half-maximal inhibitory concentration: 15500 nM
The estimate for compound 4 lay 2.6-fold (0.41 log units) above the measured number; the range from low to high includes it.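

For the compounds shown here, with (4-fluorophenyl)carbamoyl on the amine nitrogen in the ring, compound 4 gives the first value in this assay that is a number rather than a limit. Compound 1 gives > 20000 nM as a limit only. On these data alone, the change can therefore be read only as a floor, an at least 1.2-fold lower number from compound 1 to compound 4 (0.11 log units; that floor lies within the scatter) and the full size of the step stays unknown.

The compounds shown leave open which part of the swapped group matters, since several atoms change at once. As far as these compounds go, it also remains open how an amine or a carboxylic acid in place of the fluorine would read.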